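The source may hold more compounds than are shown below. What is called first, only, known or untested is meant among the compounds shown, and "the series" means these compounds.

Compound 3 `COc1cc2c(cc1NS(=O)(=O)c1cccc(Cl)c1Cl)[nH]c(=O)n2C(C)C` gives 1000 nM in a functional assay on CHO cells for antagonist activity at C-C chemokine receptor type 4 (Homo sapiens), read by radioligand binding and GTPgammaS binding (on this read-out lower numbers stand for stronger inhibition and higher numbers for weaker inhibition), the largest number shown so far, though compound 1 `COc1cccc2c1c(NS(=O)(=O)c1cccc(Cl)c1Cl)nn2C` with 603 nM in this assay lies within the scatter of it. Compound 2 `COc1cc2[nH]c(=O)[nH]c2cc1NS(=O)(=O)c1cccc(Cl)c1Cl` gives 316 nM in this assay. Within the data shown here, the only single-point step measured is a 3.2-fold higher number from compound 2 to compound 3 (0.50 log units; beyond the scatter), isopropyl in place of hydrogen on an aromatic nitrogen. Compound 4 `COc1cc2c(cc1NS(=O)(=O)c1cccc(Cl)c1Cl)[nH]c(=O)n2C1CNC1` carries azetidin-3-yl in place of isopropyl on an aromatic nitrogen: the leaving group has no ring and no donor or acceptor, the entering group brings one four-membered non-aromatic ring with 1 hetero atom, 1 hydrogen-bond donor and 1 hydrogen-bond acceptor. Among the measured compounds shown here, no measured step bears on this exchange directly; the hydrogen-to-isopropyl step only shows that substitution at this nitrogen moves the number modestly. No step beyond the scatter is expected in this assay. Compound 4 is estimated at 700 nM, range 200 nM to 2500 nM, which means a step of a 1.4-fold lower number from compound 3 to compound 4 (0.15 log units; within the scatter).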

Compound 4, half-maximal inhibitory concentration: 398 nM
Estimate against measurement, compound 4: 1.8-fold (0.25 log units) above, and the stated range covers the measured number.
By their numbers in this assay, from the lowest: compounds 2, 4, 1 and 3 (each within the scatter of the next, the first and the last beyond it).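

On this aromatic nitrogen, substitution need not raise the number in this assay: azetidin-3-yl in place of isopropyl gives a 2.5-fold lower number from compound 3 to compound 4 (0.40 log units; beyond the scatter) at a similar group size. Azetidin-3-yl in place of hydrogen gives a 1.3-fold higher number from compound 2 to compound 4 (0.10 log units; within the scatter) and so shows no readable change from the unsubstituted nitrogen, unlike isopropyl. No measured evidence explains the difference between azetidin-3-yl and isopropyl. From the compounds shown here alone, whether the ring or its nitrogen matters remains open: cyclobutyl and an open-chain amine such as 2-aminoethyl would separate the two. Larger rings such as piperidin-4-yl also remain untested here.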